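The source may hold more compounds than are shown below. What is called first, only, known or untested is meant among the compounds shown, and "the series" means these compounds.

Working notes on the series.

Compound 3 `COc1ccc(-n2cc(COc3c(/C=C\C(=O)O)ccc(OC)c3CC=C(C)C)nn2)cc1` in a functional assay on A-431 cells (Homo sapiens) for cytotoxicity, read by MTT assay, with a stated time of 24 h (on this read-out higher numbers stand for weaker inhibition and lower numbers for stronger inhibition), gives "not determined" (no result reported); nothing was determined for it, so it cannot be placed on the numbers at all. Going by the values given here, the only quantitative anchors are compound 1 `COc1cccc(-n2cc(COc3c(/C=C\C(=O)O)ccc(OC)c3CC=C(C)C)nn2)c1`, which in this assay gives 23200 nM, and compound 2 `COc1ccc(/C=C\C(=O)O)c(OCc2cn(-c3cccc(C#N)c3)nn2)c1CC=C(C)C`, which in this assay gives 22900 nM. The two values lie within the scatter of each other.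

Compound 4 `COc1ccc(/C=C\C(=O)O)c(OCc2cn(-c3ccc(C#N)cc3)nn2)c1CC=C(C)C` is derived from compound 3 by the exchange (cyano in place of methoxy on an aromatic carbon). Among the compounds with values here, the same kind of exchange, cyano in place of methoxy on an aromatic carbon, is the one measured step in the set: a 1.0-fold lower number from compound 1 to compound 2 (0.01 log units; within the scatter). That step is within the scatter and offers no reason to expect a shift in this assay beyond the scatter when the same exchange is carried out on compound 3; whether the different location of the substituent alters the outcome cannot be read from the data, since compound 3 itself has no number.

Within the data shown here, with the start point unmeasured, the estimate for compound 4 rests on the two measured members and the flat step between them. Compound 4 is expected to give 23000 nM in this assay, with a range from 8000 nM to 65000 nM.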

Compound 4, half-maximal inhibitory concentration: 23000 nM
Beside the measured number, compound 4's estimate shows no gap at the digits printed; low and high end bracket the measured number.
By their numbers in this assay, from the lowest: compounds 2, 4 and 1 (each within the scatter of the next).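

The position of the nitrile on the aryl group on the aromatic nitrogen had not been tested before this result, and in this assay, 4-cyanophenyl in place of 3-cyanophenyl gives a 1.0-fold higher number from compound 2 to compound 4 (0.00 log units; within the scatter). Changing both the group and its place, with 4-cyanophenyl in place of 3-methoxyphenyl, gives a 1.0-fold lower number from compound 1 to compound 4 (0.00 log units; within the scatter), so the series stays flat within the scatter across these three aryl groups, with neither the location of the nitrile nor the swap from a 3-methoxy to a 4-cyano substituent separating the compounds. The data offer no measurement that would explain this flatness.

The compounds shown leave open whether a group of another kind on this aryl ring, such as an amine or a carboxylic acid, would move the number beyond the scatter in this assay. They also leave open whether this read-out responds to any change elsewhere on the shared core, for example a longer chain in place of the one carried by all the compounds here.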